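The compounds below may be only part of what the source reports. "The series", "measured", "known", "first", "only" and "open" are said of these compounds alone.

Measured compounds:
Compound 1 `CCCCCCCCNC(=O)[C@H](COP(=O)(O)O)NC(=O)CCCCCCC`: in an assay on RH7777 cells with lysophosphatidic acid receptor 3 (Homo sapiens) as the target (on this read-out lower numbers stand for stronger inhibition and higher numbers for weaker inhibition), compound 1 gives 196 nM
Compound 2 `CCCCCCCCNC(=O)[C@@H](COP(=O)(O)O)NC(=O)CCCCCCC`: in this assay compound 2 gives 489 nM

Compound 1 stands at the lower of the two numbers recorded in this assay. Its nearest neighbour is compound 2, and the step of a 2.5-fold higher number from compound 1 to compound 2 (0.40 log units; beyond the scatter) rests on the fact that compounds 1 and 2 differ only in the configuration as drawn alone, the two compounds sharing every atom and bond.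

Compound 3 `CCCCCCCCNC(=O)[C@H](COP(O)(O)=S)NC(=O)CCCCCCC` differs from compound 1 by a group of 4 heavy atoms (2 oxygen, 1 phosphorus, 1 sulfur; no ring) in place of a group of 4 heavy atoms (3 oxygen, 1 phosphorus; no ring), on an oxygen on a saturated carbon. Among the compounds with values here, neither measured step concerns this exchange at the phosphorus-bearing group: the only step recorded, from compound 1 to compound 2, changes configuration and leaves the phosphate untouched, so nothing recorded bears directly on the move to a thiophosphate. With no guidance in either direction, the expected step of a 1.3-fold lower number from compound 1 to compound 3 (0.12 log units; within the scatter) is none beyond the scatter, and the uncertainty is correspondingly wide. Compound 3 is therefore estimated to give 150 nM in this assay, with a range from 40 nM to 600 nM.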

Compound 3, inhibition constant: 117 nM
Beside the measured number, compound 3's estimate is 1.3-fold (0.11 log units) above it; the measured number falls inside the stated range.
By their numbers in this assay, from the lowest: compounds 3 and 1 (each within the scatter of the next); then compound 2.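

Replacing the group of 3 oxygen and 1 phosphorus with the one of 2 oxygen, 1 phosphorus and 1 sulfur, on an oxygen on a saturated carbon, gives a step within the scatter in this assay (a 1.7-fold lower number from compound 1 to compound 3 (0.22 log units; within the scatter)). So the exchange of one oxygen for sulfur at the phosphorus leaves the number indistinguishable from that of the parent, and compound 3 and compound 1 cannot be ordered. Nothing available explains why this position accepts the sulfur.

Going by these compounds, whether the thiophosphate would show the same dependence on configuration as the phosphate (a 2.5-fold higher number from compound 1 to compound 2 (0.40 log units; beyond the scatter)) remains open. Also open, on these data alone, is how this assay would read for a carboxylic acid in place of the phosphorus-bearing group, or for a longer chain on the shared core.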